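Replacing the aryl amide of compound 3 with a hydroxyalkyl chain

The source may hold more compounds than are shown below. What is called first, only, known or untested is meant among the compounds shown, and "the series" means these compounds.

This account follows a series of amides built on a shared core. Compound 1 `CCn1c(C(=O)NCCN(C)C)ccc1C(CC)(CC)c1ccc(OCCC(O)(CC)CC)c(C)c1` gives 82 nM in an assay on cells for agonist activity at vitamin D3 receptor (Homo sapiens), with a stated time of 96 h; a lower number here means that less compound is needed, a higher number that more compound is needed for the effect. Compound 2 `CCn1c(C(=O)NCCN)ccc1C(CC)(CC)c1ccc(OCCC(O)(CC)CC)c(C)c1` gives 156 nM in this assay, and the change from compound 1 to compound 2 is a 1.9-fold higher number from compound 1 to compound 2 (0.28 log units; within the scatter). Compound 3 `CCOc1ccc(NC(=O)c2ccc(C(CC)(CC)c3ccc(OCCC(O)(CC)CC)c(C)c3)n2CC)cc1` gives 1630 nM, the highest number of the three; its nearest neighbour is compound 2, and the step from compound 2 to compound 3 is a 10-fold higher number from compound 2 to compound 3 (1.02 log units; beyond the scatter), while that from compound 1 to compound 3 is a 20-fold higher number from compound 1 to compound 3 (1.30 log units; beyond the scatter). Both steps show that putting a 4-ethoxyphenyl on the amide-type nitrogen, in place of a two-carbon chain carrying an amino or dimethylamino group, raised the number well beyond the scatter.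

Compound 4 `CCC(C)C(CO)NC(=O)c1ccc(C(CC)(CC)c2ccc(OCCC(O)(CC)CC)c(C)c2)n1CC` has not yet been measured. Its change from compound 3 is 1-(hydroxymethyl)-2-methylbutyl in place of 4-ethoxyphenyl on an amide-type nitrogen, so the aryl group on the amide-type nitrogen is again exchanged for an open chain, here one carrying a hydroxyl. The two measured steps onto the aryl amide both went upward by a large amount, so the return to a chain substituent is expected to move the number back downward, though the new chain is not the same as either of those in compound 1 or compound 2, and the size of the recovery is uncertain. For compound 4 the expected step is a 6.5-fold lower number from compound 3 to compound 4 (0.81 log units; beyond the scatter). Compound 4 is therefore estimated at 250 nM, within a range from 70 nM to 900 nM.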

Compound 4, half-maximal effective concentration: 450 nM
The estimate for compound 4 lay 1.8-fold (0.26 log units) below the measured number, within the range that was stated.
By their numbers in this assay, from the lowest: compounds 1 and 2 (each within the scatter of the next); then compound 4; then compound 3.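

In this assay, the exchange of 4-ethoxyphenyl for 1-(hydroxymethyl)-2-methylbutyl on the amide-type nitrogen gives a 3.6-fold lower number from compound 3 to compound 4 (0.56 log units; beyond the scatter), which shows that an open chain with no amino group can also bring the number down from that of the aryl amide, so the earlier recovery is not confined to chains carrying an amino or dimethylamino group. The recovery is only partial, however: there is a 2.9-fold higher number from compound 2 to compound 4 (0.46 log units; beyond the scatter) and a 5.5-fold higher number from compound 1 to compound 4 (0.74 log units; beyond the scatter), so among these compounds, having an open chain at this position does not by itself restore the numbers seen with the two aminoalkyl chains. Nothing shown here gives a reason for this order, and no measurement explains it.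

As far as these compounds go, the new chain differs from the 2-aminoethyl chain in both its branching and its end group, so it remains open whether the hydroxyl or the branched carbon skeleton sets the place of compound 4. A 2-hydroxyethyl chain or an unbranched butyl chain on the same nitrogen would separate these two features, and a 3-aminopropyl chain would test the length of the amine-bearing chain.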